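Replacing methoxycarbonyl with carboxy in compound 2

This account rests on a few compounds, and the source may have more. Where it says the series, first, only, none or still open, it means among the compounds named here.

compound 1 `COC(=O)C(C)(C)Nc1cc(NS(=O)(=O)/C=C/c2c(OC)cc(OC)cc2OC)ccc1OC`: 200 nM
compound 2 `COC(=O)C(Nc1cc(NS(=O)(=O)/C=C/c2c(OC)cc(OC)cc2OC)ccc1OC)c1ccccc1`: 2500 nM

In a functional assay on DU-145 cells (Homo sapiens) for cytotoxicity, read by trypan blue exclusion, with a stated time of 96 h (a lower number here means a stronger inhibitor, a higher number a weaker inhibitor), compound 2, at 2500 nM, has the higher of the two numbers, which makes it the weaker inhibitor of the pair. Compound 3 `COc1cc(OC)c(/C=C/S(=O)(=O)Nc2ccc(OC)c(NC(C(=O)O)c3ccccc3)c2)c(OC)c1` differs from compound 2 in one place: hydrogen in place of methyl on an oxygen next to a carbonyl group. This is hydrogen in place of methyl on an oxygen next to a carbonyl group, so methoxycarbonyl becomes carboxy. Going by the values given here, only one measured step exists, a 13-fold higher number from compound 1 to compound 2 (1.10 log units; beyond the scatter). It is large and beyond the scatter, but it keeps methoxycarbonyl unchanged, so it bears only indirectly: it shows that a change in this part of the molecule can move the number. Among the compounds with values here, no measured step covers the new change, so its direction stays open. The central expectation is a small move, an estimated 1.3-fold lower number from compound 2 to compound 3 (0.10 log units; within the scatter). For compound 3 the estimated value is 2000 nM, with an expected range from 300 nM to 10000 nM.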

Compound 3, half-maximal inhibitory concentration: 75 nM
Compound 3: middle estimate off by 27-fold (1.43 log units), on the high side, and the stated range ends above it.
By their numbers in this assay, from the lowest: compound 3; then compound 1; then compound 2.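

In this assay, going by these compounds alone, the ester on this side chain proves to be no passive feature: hydrogen in place of methyl on that oxygen, turning methoxycarbonyl into carboxy, gives a 33-fold lower number from compound 2 to compound 3 (1.52 log units; beyond the scatter), a large move that the one earlier step, which kept methoxycarbonyl in both compounds, could not show. The carboxy(phenyl)methyl group also outdoes the earlier 1-(methoxycarbonyl)-1-methylethyl group, with a 2.7-fold lower number from compound 1 to compound 3 (0.43 log units; beyond the scatter), so the weakness of compound 2 belongs to the phenyl-bearing ester and does not carry over to the phenyl-bearing acid. Nothing available here accounts for either step.

Still open, from the compounds shown here alone, is whether 1-carboxy-1-methylethyl, the same exchange made on compound 1, would bring a comparable gain. Going by these compounds, it is equally open whether a primary amide or a tetrazole in place of carboxy would keep the number near that of compound 3.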